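A few compounds are considered here, and "the series" means these few. Any claim that something is new, unique, unknown or untested is made for them only; others in the source may bear on it.

Among the measured compounds shown here, in a functional assay on A549 cells (Homo sapiens) for antiproliferative activity, read by MTT assay, with a stated time of 72 h (a higher number here means a weaker inhibitor, a lower number a stronger inhibitor), compound 2 `CC[C@H](C)[C@@H]1NC(=O)[C@]2(C)O[C@H]2C[C@@H](OC)/C(C)=C/C=C/[C@@H](C)[C@@H](c2ccccc2)OC(=O)[C@H](C(C)(C)O)NC(=O)[C@@H](Cc2cc(Cl)c(O)c(Cl)c2)NC1=O` gives 557 nM as the only actual number among the three compounds measured so far. Compound 1 `CO[C@@H]1C/C=C(\C)C(=O)N(C)[C@@H](C(C)C)C(=O)N[C@H](Cc2ccccc2)C(=O)N[C@@H](C(C)C)C(=O)O[C@H](c2ccccc2)[C@H](C)/C=C/C=C/1C` reads > 100 nM and that is a limit of the assay, not a number. Compound 3 `CO[C@@H]1C/C=C(\C)C(=O)N(C)[C@@H](C(C)C)C(=O)N[C@H](Cc2ccccc2)C(=O)N[C@@H](C(C)C)C(=O)O[C@H](c2ccccc2)C/C=C/C=C/1C` reads > 100 nM and that too is a limit. Compound 2 therefore cannot be ranked against either of them.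

Compound 4 `CO[C@@H]1C[C@@H]2O[C@@]2(C)C(=O)N[C@@H](C(C)C)C(=O)N[C@H](Cc2cc(Cl)c(O)c(Cl)c2)C(=O)N[C@@H](C(C)(C)O)C(=O)O[C@H](c2ccccc2)[C@H](C)/C=C/C=C/1C` differs from compound 2 by one change: hydrogen in place of methyl on a saturated chain carbon, two bonds along the chain from a saturated ring carbon, which turns sec-butyl into isopropyl. For the measured compounds named here, the only measured swap of methyl for hydrogen, made on a saturated ring carbon instead, is a step that the two limits leave unreadable from compound 1 to compound 3 and it offers no size to carry over. With no measured guide in either direction, no step beyond the usual scatter is expected in this assay here. The expected step is a 1.1-fold higher number from compound 2 to compound 4 (0.03 log units; within the scatter) on this estimate. Compound 4 is estimated at 600 nM with an expected range of 200 nM to 1800 nM for now.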

Compound 4, half-maximal inhibitory concentration: "not active" (no number reported)
No number was reported for compound 4; the estimate stays without a comparison.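

Among the compounds shown here, compound 4 is reported only as "not active", with no number, so no step from compound 2 to compound 4 can be read. What the change from sec-butyl to isopropyl does in this assay stays open, and the other compounds offer little firm ground for ranking: the limit of > 100 nM in this assay, at which 2 of the 4 values shown sit.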